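Thiosemicarbazone series: meta substituent change on the aryl ring

This account rests on a few compounds, and the source may have more. Where it says the series, first, only, none or still open, it means among the compounds named here.

Measured compounds:
compound 1 `CC1=CC[C@H](C(C)(C)NC(=S)N/N=C/c2ccccc2)CC1` — 53900 nM
compound 2 `CC1=CC[C@H](C(C)(C)NC(=S)N/N=C/c2cccc(Cl)c2)CC1` — 21400 nM

In a functional assay on NCI-H460 cells (Homo sapiens) for inhibition, read by sulforhodamine B assay, with a stated time of 48 h (on this read-out lower numbers stand for stronger inhibition of growth and higher numbers for weaker inhibition of growth), compound 1 gives 53900 nM. Compound 2, in this assay, gives 21400 nM. Within the data shown here, the only step between measured compounds is a 2.5-fold lower number from compound 1 to compound 2 (0.40 log units; beyond the scatter). Compound 2 therefore stands lowest of the two numbers; its nearest neighbour is compound 1, whose number is higher by that same step.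

Compound 3 `CC1=CC[C@H](C(C)(C)NC(=S)N/N=C/c2cccc([N+](=O)[O-])c2)CC1` has not yet been measured in this assay. It differs from compound 2 by nitro in place of chloro on an aromatic carbon. Among the measured compounds shown here, no measured step bears directly on this change: the single step available replaces hydrogen with chloro at the same position of the ring, and it gave a modest lowering. As far as these compounds go, whether nitro at that position behaves like chloro or like hydrogen is unknown here, so the expectation is a step no larger than the scatter in either direction.

Compound 3 is expected to give 22000 nM in this assay. The estimated range for compound 3 runs from 8000 nM to 60000 nM. The step this estimate implies is a 1.0-fold higher number from compound 2 to compound 3 (0.01 log units; within the scatter), expected to stay within the scatter.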

Compound 3, concentration for total growth inhibition: > 100000 nM
Compound 3 gave a limit, no number; the forecaster's own chance of this, stated with the estimate: 5%; middle value at least 4.5-fold (0.65 log units) from the limit.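

Compound 3 returns a limit of the assay and not a number: the limit of > 100000 nM in this assay, at which 1 of the 3 values shown sits.

Among these compounds, at this place on the aromatic ring, the earlier pair showed only that a group in place of hydrogen could lower the number. Nitro in place of chloro now gives an at least 4.6-fold higher number from compound 2 to compound 3 (0.66 log units; beyond the scatter) and so reverses the gain recorded as a 2.5-fold lower number from compound 1 to compound 2 (0.40 log units; beyond the scatter) for chloro in place of hydrogen, which shows that the read-out depends on which group stands here and that the lowering belongs to chloro, not to substitution at this place as such. Against the unsubstituted compound, nitro in place of hydrogen gives an at least 1.8-fold higher number from compound 1 to compound 3 (0.26 log units; that floor lies within the scatter) and, since that floor lies within the scatter, nitro can be said to have lost the chloro gain but not to fall clearly behind hydrogen.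

As far as these compounds go, how far compound 3 lies past its limit stays open, and with it the true size of both nitro steps. Whether an amine, a methoxy group or a carboxylic acid at this place would read with chloro or with nitro also stays open, and the three compounds give no cause for the split between chloro and nitro.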